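Swapping the thiadiazole for a triazole on the shared core

The compounds below may be only part of what the source reports. "The series", "measured", "known", "first", "only" and "open" are said of these compounds alone.

Measured compounds:
compound 1 `C#CCSc1nc(Sc2nnnn2CCN(C)C)c(C#N)c(-c2cccc(Cl)c2)n1` 4120 nM
compound 2 `C#CCSc1nc(Sc2nccs2)c(C#N)c(-c2ccc(C)cc2)n1` 2200 nM
compound 3 `C#CCSc1nc(Sc2nncs2)c(C#N)c(-c2cc(OC)c(OC)c(OC)c2)n1` 9820 nM

Three compounds sharing the same core were tested in a functional assay on MCF7 cells (Homo sapiens) for antiproliferative activity, read by MTT assay, with a stated time of 72 h; a higher number here means a weaker inhibitor, a lower number a stronger inhibitor. Compound 3 `C#CCSc1nc(Sc2nncs2)c(C#N)c(-c2cc(OC)c(OC)c(OC)c2)n1` gives the highest number of the three, 9820 nM. Compound 1 stands nearest with 4120 nM, a difference beyond the scatter, and compound 2 furthest with 2200 nM, also beyond the scatter. These three differ in more than one place, so no single change can be read from them.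

Compound 4 `C#CCSc1nc(Sc2nc[nH]n2)c(C#N)c(-c2cc(OC)c(OC)c(OC)c2)n1` differs from compound 3 in one place: 1H-1,2,4-triazol-3-yl in place of 1,3,4-thiadiazol-2-yl on a sulfur. For the measured compounds named here, no step that isolates this kind of change has been measured here. The step from compound 3 to compound 4 is therefore expected to be small, a 1.4-fold lower number from compound 3 to compound 4 (0.15 log units; within the scatter), likely within the scatter. Compound 4 is expected to give about 7000 nM, with a range from 2500 nM to 20000 nM.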

Compound 4, half-maximal inhibitory concentration: > 20000 nM
Compound 4 ended at the assay's limit; the forecaster's own chance of this, stated with the estimate: 10%; middle value at least 2.8-fold (0.45 log units) away from the limit.
By their numbers in this assay, from the lowest: compounds 2 and 1 (each within the scatter of the next); then compound 3. At a limit, above all of these: compound 4.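

In this assay, for the compounds shown here, the first step that isolates one change is an at least 2.0-fold higher number from compound 3 to compound 4 (0.30 log units; that floor lies within the scatter), with 1H-1,2,4-triazol-3-yl in place of 1,3,4-thiadiazol-2-yl on a sulfur. Compound 4 stands at a limit of the assay, so this step gives only a floor and not a size: the limit of > 20000 nM in this assay, at which 1 of the 4 values shown sits. The step comes from a single pair, so it describes this swap only with the remaining groups of compound 3.

On these data alone, it remains open how a carboxylic acid or an open-chain amine on this sulfur would read out. As far as these compounds go, whether the same swap would give a similar step with the aryl group of compound 2 also remains open.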